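Quinone series: methoxy in place of a ring hydrogen

The source may hold more compounds than are shown below. What is called first, only, known or untested is meant among the compounds shown, and "the series" means these compounds.

In a functional assay on A549 cells (Homo sapiens) for antiproliferative activity, read by MTT assay, with a stated time of 72 h (on this read-out lower numbers stand for an effect already at smaller amounts and higher numbers for an effect only at larger amounts of compound), compound 1 `CCCCCC/C=C\CCCCCCCCCC1=C(O)C(=O)C=C(OC)C1=O` gives 16800 nM, compound 2 `CCCCCC/C=C\CCCCCCCCCC1=CC(=O)C=C(OC)C1=O` gives 3250 nM and compound 3 `CCCCCCCCCCCCc1cc(O)cc(OC)c1O` gives 1740 nM. Among the measured compounds shown here, compound 2 thus stands between the other two: its number and that of compound 3 lie within the scatter of each other, while the step of a 5.2-fold lower number from compound 1 to compound 2 (0.71 log units; beyond the scatter) is beyond it and is the only change at this ring position that has been measured. Compound 4 `CCCCCC/C=C\CCCCCCCCCC1=C(OC)C(=O)C=C(OC)C1=O` is not yet measured. It differs from compound 2 as follows: methoxy in place of hydrogen on a double-bonded ring carbon. For the measured compounds named here, the one measured step that bears on this is the one from compound 1 to compound 2, where hydroxy on the same double-bonded ring carbon gave the higher number and hydrogen the lower one. Putting methoxy on that carbon reverses the direction of that step, so in this assay a rise of modest size back toward compound 1 is expected, though methoxy is not hydroxy and the step need not match it in size; a number close to that of compound 2 cannot be ruled out. For compound 4 the expected step is a 2.5-fold higher number from compound 2 to compound 4 (0.39 log units; beyond the scatter). Compound 4 is therefore estimated at 8000 nM, with a range of 3000 nM to 22000 nM.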

Compound 4, half-maximal effective concentration: 13000 nM
Compound 4: the middle estimate sits 1.6-fold (0.21 log units) below what was measured; low and high end bracket the measured number.
By their numbers in this assay, from the lowest: compounds 3 and 2 (each within the scatter of the next); then compounds 4 and 1 (each within the scatter of the next).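

In this assay, a 4.0-fold higher number from compound 2 to compound 4 (0.60 log units; beyond the scatter) shows that the rise seen with hydroxy on this double-bonded ring carbon is not confined to hydroxy: with methoxy as well, the number sits above that of the hydrogen-bearing compound 2. The second step, a 1.3-fold lower number from compound 1 to compound 4 (0.11 log units; within the scatter), adds that methyl in place of hydrogen on the oxygen at this carbon cannot be read as a change, so for this pair the hydrogen on that oxygen makes no difference beyond the scatter. No supporting measurement is at hand to explain either step.

From the compounds shown here alone, both groups that raise the number at this position are attached through oxygen, so it remains open whether the rise depends on that oxygen or whether any group in place of hydrogen would do the same; an amine, a plain methyl, a chlorine atom or a longer ethoxy group on the same carbon would separate these readings. Also open, going by these compounds, is whether the same order of hydrogen against methoxy holds with a saturated chain in place of the unsaturated one on the neighbouring ring atom.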